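Adding a ring to the side group of compound 3

The source may hold more compounds than are shown below. What is called first, only, known or untested is meant among the compounds shown, and "the series" means these compounds.

Three measured compounds show how solubility spreads in this series. In a physicochemical assay for solubility, measured as kinetic solubility (a lower number here means a less soluble compound, a higher number a more soluble compound), compound 1 `COC(c1cc(Cl)c2c(c1Cl)C(=O)N(Cc1c(C)cc(C)[nH]c1=O)CC2)C1CCOCC1` gives 57500 nM; 57200 nM (2 entries) on repeat testing. Compound 2 `Cc1cc(C)c(CN2CCc3c(Cl)cc(C(CO)C4CCOC4)c(Cl)c3C2=O)c(=O)[nH]1` gives 522000 nM; 508000 nM (2 entries) on repeat testing. Compound 3 `Cc1cc(C)c(CN2CCc3c(Cl)cc([C@@H](C)CO)c(Cl)c3C2=O)c(=O)[nH]1` gives 143000 nM in a single result, which places it between the other two. Compound 4 `Cc1cc(C)c(CN2CCc3c(Cl)cc([C@@H](CO)[C@H]4CCCO4)c(Cl)c3C2=O)c(=O)[nH]1` is still unmeasured and differs from compound 3 by a group of 8 heavy atoms (6 carbon, 2 oxygen; one five-membered non-aromatic ring with 1 hetero atom) in place of a group of 4 heavy atoms (3 carbon, 1 oxygen; no ring), on an aromatic carbon in a single place. Within the data shown here, no measured pair isolates this change, but compound 2 at 522000 nM; 508000 nM (2 entries) also carries a five-membered non-aromatic ring and has the highest value so far. A moderate rise is therefore expected, an estimated step of a 1.7-fold higher number from compound 3 to compound 4 (0.24 log units; within the scatter) upward. For compound 4 the estimated value is 250000 nM with a likely range (90000 nM to 550000 nM).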

Compound 4, solubility: 576000 nM
Beside the measured number, compound 4's estimate is 2.3-fold (0.36 log units) below it; measured number above the stated range.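

In this assay, among these compounds, the exchange on this aromatic carbon, ortho to a chloro group, gives a 4.0-fold higher number from compound 3 to compound 4 (0.61 log units; beyond the scatter) and is the first single-place comparison in this set. This position therefore takes the larger group with its five-membered non-aromatic ring, and the number rises rather than falls. Repeat entries in this series agree closely, which supports reading the step as real: the several entries of compound 2 in this assay, 522000 nM; 508000 nM (2 entries).

On these data alone, whether a carbon-only cyclopentyl ring or an amine at this position would give the same rise stays open. The part played by the two defined stereocentres of compound 4 also cannot be told apart.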